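Cyclopropyl to ethyl on the ring nitrogen of the series

The source may hold more compounds than are shown below. What is called first, only, known or untested is meant among the compounds shown, and "the series" means these compounds.

Measured compounds:
compound 1, `CCn1c(=O)n(C(=O)NCCN2CCN(C)CC2)c2ccccc21`, 6.79
compound 2, `CCCCN1CCN(CCNC(=O)n2c(=O)n(C3CC3)c3ccccc32)CC1`, 7.51

In a functional assay for antagonist activity at 5-hydroxytryptamine receptor 4 (Cavia porcellus) (on this read-out lower numbers stand for lower potency and higher numbers for higher potency (the scale is a negative logarithm)), compound 2 holds the higher of the two numbers; compound 1 sits lower by a gap beyond the scatter. For the measured compounds named here, compound 1 and compound 2 differ from each other in more than one place, so their two values show only that the pair spans a real gap and do not isolate any single change.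

Compound 3, `CCCCN1CCN(CCNC(=O)n2c(=O)n(CC)c3ccccc32)CC1`, is reached from compound 2 by ethyl in place of cyclopropyl on an aromatic nitrogen. Compound 3 thereby shares the ethyl on the aromatic nitrogen with compound 1 and differs from compound 1 only in another part of the molecule. Going by the values given here, no measured pair in the set isolates the cyclopropyl-to-ethyl exchange, so its effect is open. Given that compound 2 gives 7.51 and compound 1 gives 6.79, compound 3 is expected to land between them, and the expected step of a number 0.31 log units lower from compound 2 to compound 3 (beyond the scatter) is a small loss, likely at the edge of the scatter. The estimate for compound 3 in this assay is 7.2, with a range from 6.6 to 7.8.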

Compound 3, negative logarithm of the antagonist equilibrium constant: 7.73
The estimate for compound 3 lay 0.53 log units below the measured number; measured number inside the range.
By their numbers in this assay, from the lowest: compound 1; then compounds 2 and 3 (each within the scatter of the next).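

In this assay, ethyl in place of cyclopropyl on the aromatic nitrogen gives a number 0.22 log units higher from compound 2 to compound 3 (within the scatter) and so leaves the read-out within the scatter: on this evidence, the two groups are not told apart at this position when the rest of compound 2 is held fixed. The three-membered ring is therefore not required for the potency of compound 2, and ethyl serves as well there. The gap between compound 1 and compound 2 also gains a one-place reading, since propyl in place of hydrogen on a saturated chain carbon bound to an amine nitrogen in a ring gives a number 0.94 log units higher from compound 1 to compound 3 (beyond the scatter) as a modest gain with the ethyl held constant. No measurement on hand offers a reason for either step.

As far as these compounds go, whether this tolerance on the aromatic nitrogen reaches beyond ethyl and cyclopropyl remains open, for example to hydrogen, methyl or a longer chain such as butyl. On the amine side, the compounds shown cover only two chain lengths, so it is unknown whether a pentyl or hexyl chain, or a benzyl group, would extend the gain or reverse it.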